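Cyclohexyl for benzyl in the aryl ether of compound 3

The compounds below may be only part of what the source reports. "The series", "measured", "known", "first", "only" and "open" are said of these compounds alone.

Measured in a functional assay on the whole organism with Mus musculus as the target; a lower number here means that less compound is needed, a higher number that more compound is needed for the effect:
compound 1, `CNC(=O)[C@H](C)NCc1ccc(OCc2ccccc2)cc1`, gives 8.4 mg/kg
compound 2, `CNC(=O)[C@H](CO)NCc1ccc(OCc2ccccc2)cc1`, gives 15 mg/kg
compound 3, `C[C@@H](NCc1ccc(OCCc2ccccc2)cc1)C(N)=O`, gives 24.9 mg/kg

Compound 3 gives the highest of the three numbers in this assay; its gap to compound 2 is within the scatter, while its gap to compound 1 lies beyond it. Compound 4, `C[C@@H](NCc1ccc(OCC2CCCCC2)cc1)C(N)=O`, differs from compound 3 by cyclohexyl in place of benzyl on a saturated chain carbon bound to an oxygen on an aromatic ring. For the measured compounds named here, the one step measured in a single place, a 1.8-fold higher number from compound 1 to compound 2 (0.25 log units; within the scatter), concerns the hydroxy on the chain and leaves this position untouched, so no measured step bears on the change. Compound 4 is therefore expected to show a step of a 1.0-fold higher number from compound 3 to compound 4 (0.00 log units; within the scatter), nothing beyond the scatter, with a wide range. Compound 4 is estimated at 25 mg/kg, between 10 mg/kg and 60 mg/kg.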

Compound 4, dose for half-maximal effect: 131 mg/kg
The estimate for compound 4 lay 5.2-fold (0.72 log units) below the measured number; measured number outside the range, above it.
By their numbers in this assay, from the lowest: compounds 1, 2 and 3 (each within the scatter of the next, the first and the last beyond it); then compound 4.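

In this assay this position proves not to be indifferent to the ring it carries: cyclohexyl in place of benzyl gives a 5.3-fold higher number from compound 3 to compound 4 (0.72 log units; beyond the scatter), a step beyond the scatter. More compound is needed once the six-membered aromatic ring gives way to a non-aromatic one, though this rests on a single pair. Nothing measured here accounts for the step. Still open, as far as these compounds go, is whether a pyridine ring or a longer chain at this place would hold the number of compound 3, and whether the same exchange would cost as much in the methyl amide of compound 1.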